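This account rests on a few compounds, and the source may have more. Where it says the series, first, only, none or still open, it means among the compounds named here.

Measured compounds in a functional assay on HGC-27 cells (Homo sapiens) for inhibition, read by MTT assay, with a stated time of 72 h; on this read-out lower numbers stand for stronger inhibition and higher numbers for weaker inhibition:
compound 1 `Cc1cc(N2CC[C@@H](C)[C@@H](N(C)c3ncnc4[nH]ccc34)C2)n2nc(SCc3ccccc3)nc2n1` gives 13900 nM
compound 2 `Cc1cc(N2CC[C@@H](C)[C@@H](N(C)c3ncnc4[nH]ccc34)C2)n2nc(SCc3ccc(Cl)cc3)nc2n1` gives 18400 nM
compound 3 `Cc1cc(N2CC[C@@H](C)[C@@H](N(C)c3ncnc4[nH]ccc34)C2)n2nc(SCc3ccc(Br)cc3)nc2n1` gives 19500 nM

Compound 1 holds the lowest of the three numbers, yet the steps of a 1.3-fold higher number from compound 1 to compound 2 (0.12 log units; within the scatter) and a 1.4-fold higher number from compound 1 to compound 3 (0.15 log units; within the scatter) are both within the scatter, as is a 1.1-fold higher number from compound 2 to compound 3 (0.03 log units; within the scatter), so the three measured compounds cannot be told apart in this assay.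

Compound 4 `C#CSc1nc2nc(C)cc(N3CC[C@@H](C)[C@@H](N(C)c4ncnc5[nH]ccc45)C3)n2n1` has not been measured. It differs from compound 1 in one place: ethynyl in place of benzyl on a sulfur. For the measured compounds named here, none of the measured steps bears on this change. Going by the values given here, all three of them exchange one hydrogen or halogen on the aromatic ring of the benzyl group, and each of them stays within the scatter; no measured pair touches the sulfur substituent itself or removes the ring. There is therefore nothing in the data that points to a step beyond the scatter in this assay in either direction, and the expectation for compound 4 rests on compound 1 alone.

Compound 4 is thus expected to give about 15000 nM, with a wide range from 4000 nM to 55000 nM. This expectation corresponds to the step of a 1.1-fold higher number from compound 1 to compound 4 (0.03 log units; within the scatter).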

Compound 4, half-maximal inhibitory concentration: 35100 nM
The estimate for compound 4 lay 2.3-fold (0.37 log units) below the measured number; measured number inside the range.
By their numbers in this assay, from the lowest: compounds 1, 2, 3 and 4 (each within the scatter of the next, the first and the last beyond it).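

For the compounds shown here, exchanging the entire benzyl group on the sulfur, aromatic ring included, gives the only step in this assay that lies beyond the scatter (a 2.5-fold higher number from compound 1 to compound 4 (0.40 log units; beyond the scatter)), a modest move towards weaker inhibition. Measured against the halogen-bearing benzyl compounds, the same kind of exchange stays within the scatter (a 1.9-fold higher number from compound 2 to compound 4 (0.28 log units; within the scatter); a 1.8-fold higher number from compound 3 to compound 4 (0.26 log units; within the scatter)), so compound 4 separates from compound 1 alone, and the sulfur substituent tolerates this large change with little effect on a number that was already weak. No measurement shown accounts for this step.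

The compounds shown leave open whether the step goes with losing the aromatic ring or with gaining the triple bond. A plain methyl, a propargyl or a phenethyl chain on the sulfur would be needed to separate those two changes.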